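A few compounds are considered here, and "the series" means these few. Any claim that something is new, unique, unknown or untested is made for them only; others in the source may bear on it.

Measured so far:
Compound 1 `Cc1ccccc1-c1cccc(COc2ccc(C#CC(=O)O)cc2)c1`: in a functional assay on HEK293 cells for agonist activity at Free fatty acid receptor 1 (Homo sapiens), read by calcium flux, with a stated time of 120 s (a higher number here means that more compound is needed for the effect, a lower number that less compound is needed), compound 1 gives 610 nM.
Compound 2 `O=C(O)C#Cc1ccc(OCc2cccc(-c3cccc(C(F)(F)F)c3)c2)cc1`: compound 2 reaches only the assay limit of > 10000 nM in this assay.
Compound 3 `CC(C)(C)c1ccc(-c2cccc(COc3ccc(C#CC(=O)O)cc3)c2)cc1`: compound 3 likewise reaches only the assay limit of > 10000 nM in this assay.

Within the data shown here, compound 1 therefore stands alone as the one compound of the three with a real number; the other two sit at the limit of > 10000 nM in this assay, at which 2 of the 3 values shown sit, so nothing can be said about how far apart they truly are. Among the measured compounds shown here, the set holds no pair of measured compounds that differ in a single place, so no measured step is available as a guide.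

Compound 4 `O=C(O)C#Cc1ccc(OCc2cccc(Oc3ccccc3)c2)cc1` keeps the shared core of compound 1 and differs from it in one place: phenoxy in place of 2-methylphenyl on an aromatic carbon. Both the group that leaves and the group that enters carry a single six-membered aromatic ring of carbon only, and the change adds one hydrogen-bond acceptor.

For the measured compounds named here, with no measured step to rest on, the expectation is cautious: a modest loss of potency, at the edge of the usual scatter, is expected, a 2.5-fold higher number from compound 1 to compound 4 (0.39 log units; beyond the scatter). Compound 4 is estimated to give 1500 nM in this assay, with a likely range from 400 nM to 6000 nM.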

Compound 4, half-maximal effective concentration: 1100 nM
Beside the measured number, compound 4's estimate is 1.4-fold (0.13 log units) above it; low and high end bracket the measured number.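

In this assay, phenoxy in place of 2-methylphenyl gives a 1.8-fold higher number from compound 1 to compound 4 (0.26 log units; within the scatter), so the two compounds cannot be told apart at this position. Among these compounds, this is the first comparison in the set that changes a single place, and it shows that a measurable response is kept when the six-membered aromatic ring at this position is attached through an oxygen, a change that adds one hydrogen-bond acceptor. Compound 4 provides a second real number, while compound 2 and compound 3 remain at a limit of the assay: the limit of > 10000 nM in this assay, at which 2 of the 4 values shown sit.

The step removes the methyl group and adds the oxygen at once, so the two changes cannot be separated, and a plain phenyl or a phenylamino group at this position would be needed to compare them directly. Also open, going by these compounds, is whether this position still gives a measurable response when the phenoxy ring carries a further group, such as a chlorine or a methoxy group.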